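Aryl substituent swaps on the shared core

The compounds below may be only part of what the source reports. "The series", "measured", "known", "first", "only" and "open" are said of these compounds alone.

Measured so far, all in a functional assay on NCI-H460 cells (Homo sapiens) for antiproliferative activity, with a stated time of 72 h; a higher number here means a weaker inhibitor, a lower number a stronger inhibitor:
compound 1, `C=CC[C@H]1C[C@]2([C@@H](C)Cc3ccc(OC)c(C)c3)OCOC2=CC1=O`: 630 nM
compound 2, `C=CC[C@H]1C[C@]2([C@@H](C)Cc3ccc(OC)c(C(N)=O)c3)OCOC2=CC1=O`: 66 nM
compound 3, `C=CC[C@H]1C[C@]2([C@@H](C)Cc3ccc(OC)c(Cl)c3)OCOC2=CC1=O`: 640 nM

Compound 3 carries the highest of the three numbers. Its step from compound 1 is a 1.0-fold higher number from compound 1 to compound 3 (0.01 log units; within the scatter), so the two cannot be told apart; the step from compound 2 is a 9.7-fold higher number from compound 2 to compound 3 (0.99 log units; beyond the scatter), a clear gap, matching the step of a 9.5-fold lower number from compound 1 to compound 2 (0.98 log units; beyond the scatter) seen when the carbamoyl group enters.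

Compound 4 is `C=CC[C@H]1C[C@]2([C@@H](C)Cc3ccc(OC)c(F)c3)OCOC2=CC1=O`. It differs from compound 3 by fluoro in place of chloro on an aromatic carbon.

Among the compounds with values here, no measured step involves a fluoro group. Within the data shown here, the only step that bears on a small neutral group at this position is a 1.0-fold higher number from compound 1 to compound 3 (0.01 log units; within the scatter), where chloro and methyl gave indistinguishable numbers; the large shifts came only with the carbamoyl group of compound 2. A swap of one halogen for another at the same carbon is therefore expected to stay within the scatter, with no direction favoured.

Compound 4 is estimated at 600 nM in this assay, with a range of 250 nM to 1500 nM, meaning an expected step of a 1.1-fold lower number from compound 3 to compound 4 (0.03 log units; within the scatter).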

Compound 4, half-maximal inhibitory concentration: 90 nM
Estimate against measurement, compound 4: 6.7-fold (0.82 log units) above; measured number outside the range, below it.
By their numbers in this assay, from the lowest: compounds 2 and 4 (each within the scatter of the next); then compounds 1 and 3 (each within the scatter of the next).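

In this assay, the identity of the halogen on this aromatic carbon, ortho to a methoxy group, matters: a 7.1-fold lower number from compound 3 to compound 4 (0.85 log units; beyond the scatter), and a 7.0-fold lower number from compound 1 to compound 4 (0.85 log units; beyond the scatter), so chloro and methyl stay together while fluoro parts from both. The low number is also no longer tied to the carbamoyl group alone, since a 1.4-fold higher number from compound 2 to compound 4 (0.13 log units; within the scatter), leaving fluoro and carbamoyl indistinguishable at this carbon even though they have little else in common by name or size. Nothing available on these compounds accounts for the gap between fluoro and chloro.

Still open, going by these compounds, is whether the low number is particular to fluoro and carbamoyl or extends to other groups on this carbon, such as a hydroxyl, a nitrile, an amine or a carboxylic acid. Also open is whether the fluoro effect depends on the methoxy group, as the compounds shown all keep it, so a fluoro compound with an ethoxy group or a hydrogen in its place would be needed to separate the two.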